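This account rests on a few compounds, and the source may have more. Where it says the series, first, only, none or still open, it means among the compounds named here.

Compound 1 `O=C(/C=C/c1ccc([N+](=O)[O-])o1)c1ccc(I)cc1`: 5200 nM
Compound 2 `O=C(/C=C/c1ccc([N+](=O)[O-])o1)c1ccc(N2CCCC2)cc1`: 35400 nM
Compound 3 `O=C(/C=C/c1ccc([N+](=O)[O-])o1)c1ccc(C2CCCCC2)cc1`: 9500 nM

In a functional assay on U-87MG ATCC cells for inhibition, with U-87 MG (Homo sapiens) as the target, read by sulforhodamine B assay, with a stated time of 72 h (on this read-out lower numbers stand for an effect already at smaller amounts and higher numbers for an effect only at larger amounts of compound), the position of compound 3 is set by two steps: a 1.8-fold higher number from compound 1 to compound 3 (0.26 log units; within the scatter) stays within the scatter, while a 3.7-fold lower number from compound 2 to compound 3 (0.57 log units; beyond the scatter) goes beyond it.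

Compound 4 `O=C(/C=C/c1ccc([N+](=O)[O-])o1)c1ccc(N2CCNCC2)cc1` has piperazin-1-yl in place of cyclohexyl on an aromatic carbon.

Compound 2 carries pyrrolidin-1-yl, likewise a non-aromatic ring holding nitrogen. Two modest steps bear on the change: a 3.7-fold lower number from compound 2 to compound 3 (0.57 log units; beyond the scatter), read in reverse, and a 6.8-fold higher number from compound 1 to compound 2 (0.83 log units; beyond the scatter). This is a single precedent, so the expectation is loose.

In this assay a modest rise is expected, estimated as a 2.1-fold higher number from compound 3 to compound 4 (0.32 log units; beyond the scatter). The estimated value for compound 4 is 20000 nM, with an expected range of 6000 nM to 60000 nM.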

Compound 4, half-maximal effective concentration: 4900 nM
Estimate against measurement, compound 4: 4.1-fold (0.61 log units) above; measured number below the stated range.
By their numbers in this assay, from the lowest: compounds 4, 1 and 3 (each within the scatter of the next); then compound 2.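

In this assay, a nitrogen-bearing non-aromatic ring on this aromatic carbon carries no general penalty: the change between the two such rings gives a 7.2-fold lower number from compound 2 to compound 4 (0.86 log units; beyond the scatter). Piperazin-1-yl stays level with both cyclohexyl, at a 1.9-fold lower number from compound 3 to compound 4 (0.29 log units; within the scatter), and iodo, at a 1.1-fold lower number from compound 1 to compound 4 (0.03 log units; within the scatter), so among these compounds only pyrrolidin-1-yl stands apart. No measurement at hand accounts for the gap between the two nitrogen-bearing rings.

As far as these compounds go, whether that gap tracks the ring's size or its second nitrogen stays open. Piperidin-1-yl and morpholin-4-yl on this carbon would help separate the two.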